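A Second Aromatic Swap on the Ring Nitrogen

This account rests on a few compounds, and the source may have more. Where it says the series, first, only, none or still open, it means among the compounds named here.

Of the compounds shown here, three that share one core have been measured in a functional assay on CHO cells with adenosine receptor A1 (Homo sapiens) as the target, read by cAMP accumulation and immunoassay, with a stated time of 6 min, tested at 0.1 uM; a lower number here means a stronger effect, a higher number a weaker effect of the compound at the concentration tested. Compound 1 `CC(C)N1CCN(Cc2csc(N)c2C(=O)c2ccc(Cl)cc2)CC1` gives 3.6%. Compound 2 `Nc1scc(CN2CCN(c3cc(Cl)cc(Cl)c3)CC2)c1C(=O)c1ccc(Cl)cc1` gives -22%, and compound 3 `Nc1scc(CN2CCN(c3ccc([N+](=O)[O-])cc3)CC2)c1C(=O)c1ccc(Cl)cc1` gives -13%. On these numbers compound 3 stands second highest of the three: its nearest neighbour is compound 2, with a number 9 percentage points higher from compound 2 to compound 3 (within the scatter) lying within the scatter, while its furthest neighbour is compound 1, with a number 16.6 percentage points lower from compound 1 to compound 3 (beyond the scatter) lying beyond it.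

Compound 4 `Nc1scc(CN2CCN(c3ccc(F)cc3F)CC2)c1C(=O)c1ccc(Cl)cc1` has not yet been measured. It differs from compound 3 in one place: 2,4-difluorophenyl in place of 4-nitrophenyl on an amine nitrogen in a ring.

Two of the measured steps exchange isopropyl for an aromatic group, a number 25.6 percentage points lower from compound 1 to compound 2 (beyond the scatter) and a number 16.6 percentage points lower from compound 1 to compound 3 (beyond the scatter), and each of them is modest but beyond the scatter. For the measured compounds named here, the one step that exchanges one aromatic group for another, a number 9 percentage points higher from compound 2 to compound 3 (within the scatter), stays within the scatter. The change from compound 3 to compound 4 is again an exchange of one aromatic group for another, so the expected step is a number 1 percentage points lower from compound 3 to compound 4 (within the scatter), a shift not beyond the scatter in this assay. Compound 4 is therefore estimated at -14%, with a likely range from -34% to 6%.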

Compound 4, a percentage reported as activity, at one concentration (the size of the read-out at that concentration, not a potency): -17%
For compound 4 the middle estimate is 3 percentage points above the measured one, and the stated range covers the measured number.
By their numbers in this assay, from the lowest: compounds 2, 4 and 3 (each within the scatter of the next); then compound 1.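

In this assay, a third aromatic group on the ring nitrogen lands within the scatter of the other two, with a number 4 percentage points lower from compound 3 to compound 4 (within the scatter) and a number 5 percentage points higher from compound 2 to compound 4 (within the scatter). This exchange is a different kind of test from the earlier one between aromatic groups: 4-nitrophenyl, with 2 hydrogen-bond acceptors, leaves, and 2,4-difluorophenyl, with 0 hydrogen-bond acceptors, enters, yet the read-out does not separate the two compounds. The step from isopropyl, a number 20.6 percentage points lower from compound 1 to compound 4 (beyond the scatter), is modest but beyond the scatter, so all three steps from isopropyl to an aromatic group now point the same way, while the three compounds with an aromatic group remain within the scatter of one another.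

Nothing shown here explains why these aromatic groups read alike or why they differ from isopropyl. From the compounds shown here alone, it also remains open whether the separation from compound 1 holds for a plain phenyl or a cyclohexyl group, or for a longer alkyl chain, and a read-out at one concentration cannot show whether the compounds with an aromatic group differ in potency.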